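This account rests on a few compounds, and the source may have more. Where it says the series, first, only, none or still open, it means among the compounds named here.

Measured in a functional assay on MV4-11 cells (Homo sapiens) for inhibition, read by resazurin assay, with a stated time of 72 h; on this read-out lower numbers stand for stronger inhibition of growth and higher numbers for weaker inhibition of growth:
- Compound 1 `COc1ccc(Nc2nccc(-c3sc(SC)nc3C)n2)c(OC)c1`: 530 nM
- Compound 2 `Oc1ccccc1Nc1nccc(-c2c[nH]c3ccccc23)n1`: 570 nM

The values of compound 1 and compound 2 lie within the usual scatter of each other, so the two cannot be ranked. Going by the values given here, compound 1 therefore stands level with the only other measured compound. The next compound to be tested, compound 3 `CNc1nc(C)c(-c2ccnc(Nc3ccc(OC)cc3OC)n2)s1`, keeps the core of compound 1 and alters a single group: methylamino in place of methylsulfanyl on an aromatic carbon. Methylamino stands in place of methylsulfanyl on an aromatic carbon, next to the ring nitrogen and next to the ring sulfur.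

Among the compounds with values here, no two measured compounds differ in just one place, so no measured step shows how much such a change matters in this assay, and any forecast is uncertain. A moderate move towards stronger growth inhibition is expected, starting from compound 1 at 530 nM. The expected step is a 2.1-fold lower number from compound 1 to compound 3 (0.33 log units; beyond the scatter). For compound 3 the estimated value is 250 nM, with an expected range from 60 nM to 900 nM.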

Compound 3, concentration for 50% growth inhibition: 300 nM
Compound 3: the middle estimate sits 1.2-fold (0.08 log units) below what was measured; the range from low to high includes it.
By their numbers in this assay, from the lowest: compounds 3, 1 and 2 (each within the scatter of the next).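

In this assay, going by these compounds alone, this is the first step that changes only one place, the aromatic carbon next to the ring nitrogen and next to the ring sulfur. Methylamino in place of methylsulfanyl gives a 1.8-fold lower number from compound 1 to compound 3 (0.25 log units; within the scatter), so compound 3 and compound 1 cannot be ranked, even though a hydrogen-bond donor enters and a nitrogen takes the place of a sulfur. At this position, then, the exchange leaves growth inhibition level within the scatter, and 4-methyl-2-(methylamino)-1,3-thiazol-5-yl serves as well as 4-methyl-2-(methylsulfanyl)-1,3-thiazol-5-yl, although nothing available explains why the two read alike.

The compounds shown leave open whether any group at this position can move the number beyond the scatter, for example dimethylamino, ethylamino, a longer chain such as butylamino, or a plain amine. Within the data shown here, they also leave open whether the same exchange would give a similar step on a core other than that of compound 1, since this single pair is the only evidence for it.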